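A Larger Ring Group Replaces the Methylpiperazine

The compounds below may be only part of what the source reports. "The series", "measured", "known", "first", "only" and "open" are said of these compounds alone.

Compound 1 `O=C(Nc1cccc(F)c1)c1cc(C(F)(F)F)ccc1OCc1ccc(F)cc1` gives 31.6 nM in an assay on Sf9 cells for inhibition of Leucine-rich repeat serine/threonine-protein kinase 2 (Homo sapiens), read by TR-FRET, with stated times of 30 min and 2 h; a lower number here means a stronger inhibitor, a higher number a weaker inhibitor.
Compound 2 `O=C(Nc1ccnnc1)c1cc(N2CCC(F)CC2)ccc1OCc1ccccc1` gives 39.8 nM in this assay.
Compound 3 `CN1CCN(c2ccc(OCc3ccccc3)c(C(=O)Nc3ccnnc3)c2)CC1` gives 12.6 nM in this assay.

Among these three, compound 3 gives the lowest number, and its gap to each of the others lies beyond the scatter, so it is the strongest inhibitor measured here. Compound 4 `CN1CC2(CCN(c3ccc(OCc4ccccc4)c(C(=O)Nc4ccnnc4)c3)CC2)C1` carries a group of 10 heavy atoms (8 carbon, 2 nitrogen; one four-membered non-aromatic ring with 1 hetero atom, one six-membered non-aromatic ring with 1 hetero atom) in place of a group of 7 heavy atoms (5 carbon, 2 nitrogen; one six-membered non-aromatic ring with 2 hetero atoms), on an aromatic carbon. Among the measured compounds shown here, the only measured step at this position is a 3.2-fold lower number from compound 2 to compound 3 (0.50 log units; beyond the scatter), where a 4-methylpiperazin-1-yl replaced a 4-fluoropiperidin-1-yl. The change to compound 4 keeps a nitrogen-containing ring bearing a methyl-substituted nitrogen, so the new group is not directly covered by that step. With one step for guidance, the expectation is a small shift, likely within the scatter, expressed as a 1.3-fold higher number from compound 3 to compound 4 (0.10 log units; within the scatter). Compound 4 is therefore estimated at 16 nM, with a range from 6 nM to 45 nM in this assay.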

Compound 4, half-maximal inhibitory concentration: 63.1 nM
The estimate for compound 4 lay 3.9-fold (0.60 log units) below the measured number; measured number above the stated range.
By their numbers in this assay, from the lowest: compound 3; then compounds 1, 2 and 4 (each within the scatter of the next).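

Placing the larger two-ring group at this position in place of the 4-methylpiperazin-1-yl gives a 5.0-fold higher number from compound 3 to compound 4 (0.70 log units; beyond the scatter) in this assay, so a methyl-bearing nitrogen ring alone does not preserve the number seen for compound 3. The same group in place of the 4-fluoropiperidin-1-yl gives a 1.6-fold higher number from compound 2 to compound 4 (0.20 log units; within the scatter) and so cannot be told apart from it. No measurement shown here explains the rise from compound 3 to compound 4. Still open, from the compounds shown here alone, is how a morpholine or an unsubstituted piperazine would compare at this position, and whether the methyl on the nitrogen matters.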